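The source may hold more compounds than are shown below. What is called first, only, known or untested is meant among the compounds shown, and "the series" means these compounds.

Measured in a functional assay on MV4-11 cells (Homo sapiens) for antiproliferative activity, read by CCK-8 assay, with a stated time of 72 h; a higher number here means a weaker inhibitor, a lower number a stronger inhibitor:
- compound 1 `Cc1cc(F)cc(C)c1Oc1ccc(C(C)(C)O)cc1-c1cn(C)c(=O)c2[nH]c(C(=O)NCc3ccc(C(=O)NO)cc3)cc12` gives 440 nM
- compound 2 `Cc1cc(F)cc(C)c1Oc1ccc(C(C)(C)O)cc1-c1cn(C)c(=O)c2[nH]c(C(=O)NCc3ccc(C(=O)Nc4ccccc4N)cc3)cc12` gives 240 nM

For the measured compounds named here, compound 1 stands level with compound 2 on these numbers, with a 1.8-fold lower number from compound 1 to compound 2 (0.26 log units; within the scatter) as the only measured step, so the two cannot be ranked. Not yet measured is compound 3 `Cc1cc(F)cc(C)c1Oc1ccc(C(C)(C)O)cc1-c1cn(C)c(=O)c2[nH]c(C(=O)NCCCCCCC(=O)NO)cc12`, where the change from compound 1 is 5-(hydroxycarbamoyl)pentyl in place of 4-(hydroxycarbamoyl)phenyl on a saturated chain carbon bound to an amide-type nitrogen and the ring-bearing group gives way to an open chain. The measured step bears on this only loosely, since it alters the hydroxy end of the group and leaves the ring in place. Going by the values given here, no measured step covers a ring-to-chain exchange, so the range must stay wide. In this assay, no step beyond the scatter is expected, in either direction. The estimated step is a 1.3-fold lower number from compound 1 to compound 3 (0.10 log units; within the scatter) and carries little weight. Compound 3 is expected at 350 nM with an estimated range of 120 nM to 1000 nM in this series.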

Compound 3, half-maximal inhibitory concentration: 300 nM
Compound 3: the middle estimate sits 1.2-fold (0.07 log units) above what was measured; measured number inside the range.
By their numbers in this assay, from the lowest: compounds 2, 3 and 1 (each within the scatter of the next).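

In this assay, 5-(hydroxycarbamoyl)pentyl in place of 4-(hydroxycarbamoyl)phenyl on a saturated chain carbon bound to an amide-type nitrogen gives a 1.5-fold lower number from compound 1 to compound 3 (0.17 log units; within the scatter) and so stays within the scatter. The earlier step changed only the end of the group and kept the ring in place, whereas this one shows that the six-membered aromatic ring can give way to an open chain at this position with no step beyond the scatter, at least with the hydroxycarbamoyl end kept. Nothing at hand gives a reason for this result. Still open, going by these compounds, is whether the 2-aminophenyl amide end of compound 2 would hold up on the open chain. Also open, on these data alone, are a longer chain such as 7-(hydroxycarbamoyl)heptyl, a shorter chain such as 3-(hydroxycarbamoyl)propyl, and a carboxylic acid in place of the hydroxycarbamoyl end.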